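This account rests on a few compounds, and the source may have more. Where it says the series, first, only, none or still open, it means among the compounds named here.

Compound 1 `Cc1c(OCCCCOc2cccc(C(=O)O)c2)ccc(C(=O)CC(C)C)c1C` acts as a positive allosteric modulator of a glutamate receptor. Going by the values given here, in an assay on HEK293 cells for positive allosteric modulation of metabotropic glutamate receptor 3 (Rattus norvegicus), read by thallium flux, with a stated time of 2.5 min (on this read-out lower numbers stand for smaller maximal responses and higher numbers for larger maximal responses), compound 1 gives 18.3%, one of only two numbers so far. Compound 2 `COC(=O)c1ccc(OCCCCOc2ccc(C(=O)CC3CCCC3)c(C)c2C)cc1` gives 24.2% in this assay, a value within the usual scatter of compound 1. Compound 3 `Cc1c(OCCCCOc2ccc(C(=O)O)cc2)ccc(C(=O)CC(C)C)c1C` differs from compound 1 in one place: 4-carboxyphenyl in place of 3-carboxyphenyl on an oxygen on a saturated carbon. Among the compounds with values here, no measured pair shows such a change, so no step beyond the scatter is expected in either direction. The expected step is a number 3.7 percentage points higher from compound 1 to compound 3 (within the scatter). Compound 3 is therefore estimated at 22%, between 10% and 40%.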

Compound 3, largest response reached (reported as percent of maximum), in percent of the reference or control that the assay uses: 16.6%
Estimate against measurement, compound 3: 5.4 percentage points above; measured number inside the range.
By their numbers in this assay, from the lowest: compounds 3, 1 and 2 (each within the scatter of the next).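

In this assay, putting 4-carboxyphenyl in place of 3-carboxyphenyl gives a number 1.7 percentage points lower from compound 1 to compound 3 (within the scatter) and so leaves the maximal response unchanged within the usual scatter. Going by these compounds alone, this is the first measured pair that isolates this change, and at this place the read-out does not tell the two groups apart. No available evidence bears on this result.

Still open, going by these compounds, is whether an amide or an amine in place of the carboxylic acid would move the response beyond the scatter.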